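Halogen on the second phenyl of the pyrazoline series

The source may hold more compounds than are shown below. What is called first, only, known or untested is meant among the compounds shown, and "the series" means these compounds.

Compound 2 `Fc1ccc(C2CC(c3ccccc3)=NN2c2ccc(-c3ccccc3)nn2)cc1` gives 89200 nM in a functional assay on A549 cells (Homo sapiens) for antiproliferative activity, read by MTT assay, with a stated time of 24 h; on this read-out lower numbers stand for stronger inhibition and higher numbers for weaker inhibition; its number stands with that of compound 1 `Clc1ccc(C2CC(c3ccccc3)=NN2c2ccc(-c3ccccc3)nn2)cc1`, which gives 100000 nM, the step of a 1.1-fold lower number from compound 1 to compound 2 (0.05 log units; within the scatter) lying within the scatter. Compound 3 `Fc1ccc(C2CC(c3ccc(Cl)cc3)=NN2c2ccc(-c3ccccc3)nn2)cc1` differs from compound 2 by chloro in place of hydrogen on an aromatic carbon. Among the measured compounds shown here, no measured step bears directly on this change; the one step in hand, a halogen swap on the other phenyl, was flat. The step of a 1.0-fold lower number from compound 2 to compound 3 (0.02 log units; within the scatter) is therefore expected to stay within the scatter. Compound 3 is estimated at 85000 nM, range 40000 nM to 170000 nM.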

Compound 3, half-maximal inhibitory concentration: > 100000 nM
Compound 3: a limit, no number (the forecaster's own chance of this, stated with the estimate: 20%); middle value at least 1.1-fold (0.07 log units) from the limit.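

Phenyl to 4-chlorophenyl, para to a large group, gives an at least 1.1-fold higher number from compound 2 to compound 3 (0.04 log units; that floor lies within the scatter), so this first change on the second aryl ring brings no lower number in this assay. How far the number rises cannot be read, since only the floor of the step is fixed. Compound 3 carries a limit, not a number: the limit of > 100000 nM in this assay, at which 1 of the 3 values shown sits.

As far as these compounds go, whether any group at this position can lower the number stays open. An amine or a carboxylic acid in place of chloro would test this, and either could be set against compound 2.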